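The compounds below may be only part of what the source reports. "The series", "measured", "known", "first", "only" and "open" are said of these compounds alone.

Of the compounds shown here, three sharing one core have been measured in a functional assay on UO-31 cells (Homo sapiens) for inhibition, read by sulforhodamine B assay, with a stated time of 48 h; on this read-out higher numbers stand for weaker inhibition of growth and lower numbers for stronger inhibition of growth. Compound 1 `COc1cc(-c2nn(-c3cccc(NC(=O)Nc4ccc(Cl)c(Cl)c4)c3)cc2-c2ccncc2)ccc1Cl` gives 845 nM. Compound 2 `O=C(Nc1cccc(-n2cc(-c3ccncc3)c(-c3ccc(Cl)c(O)c3)n2)c1)Nc1ccc(Cl)c(Cl)c1`, which has hydrogen in place of methyl on an oxygen on an aromatic ring, gives 1250 nM; that change reads a 1.5-fold higher number from compound 1 to compound 2 (0.17 log units; within the scatter). Compound 3 `COc1cc(-c2nn(-c3cccc(NC(=O)c4ccccc4)c3)cc2-c2ccncc2)ccc1Cl`, with phenyl in place of (3,4-dichlorophenyl)amino on a carbonyl carbon, gives 638 nM; that change reads a 1.3-fold lower number from compound 1 to compound 3 (0.12 log units; within the scatter). Compound 2 sits within the scatter of both compound 1 and compound 3, so no order among the three can be read from these numbers.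

Compound 4 `O=C(Nc1cccc(-n2cc(-c3ccncc3)c(-c3ccc(Cl)c(O)c3)n2)c1)Nc1ccc(Cl)c(C(F)(F)F)c1` has not yet been measured. It differs from compound 2 in one place: trifluoromethyl in place of chloro on an aromatic carbon. Among the measured compounds shown here, no measured step touches this position. The nearest comparison is the replacement of the whole (3,4-dichlorophenyl)amino by phenyl, which gave only a 1.3-fold lower number from compound 1 to compound 3 (0.12 log units; within the scatter), while the other step, a 1.5-fold higher number from compound 1 to compound 2 (0.17 log units; within the scatter), lies elsewhere on the core and is also within the scatter. Because a 1.3-fold lower number from compound 1 to compound 3 (0.12 log units; within the scatter) and a 1.5-fold higher number from compound 1 to compound 2 (0.17 log units; within the scatter) both leave the number essentially unchanged, the expected step for compound 4 is no change at the digits printed from compound 2 to compound 4 (within the scatter), that is, none beyond the scatter. Compound 4 is therefore estimated to give 1250 nM in this assay, with a range from 500 nM to 3000 nM.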

Compound 4, concentration for 50% growth inhibition: 777 nM
Compound 4: the middle estimate sits 1.6-fold (0.21 log units) above what was measured; the measured number falls inside the stated range.
By their numbers in this assay, from the lowest: compounds 3, 4, 1 and 2 (each within the scatter of the next).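

In this assay, among the compounds shown here, the earlier compounds had touched this end of the molecule only by replacing the whole (3,4-dichlorophenyl)amino, so the chloro ortho to a chloro group had not been varied on its own until this pair. Trifluoromethyl, with more heavy atoms than the chloro it replaces, gives a 1.6-fold lower number from compound 2 to compound 4 (0.21 log units; within the scatter), so in this single pair the exchange at this aromatic carbon, meta to a large group, leaves the read-out within the scatter and shows that the larger group is accepted here without a readable loss of growth inhibition. Nothing at hand explains this result or ties it to any property of either group.

The compounds shown leave open whether the same exchange would also stay within the scatter on the methoxy-bearing partner, compound 1, or on the benzamide-type end of compound 3, where this aromatic ring is absent. They also leave open whether a group of another kind at this place, such as an amine, a carboxylic acid or a nitrile, would move the number beyond the scatter, and what the chloro that stays in place contributes.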